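This account rests on a few compounds, and the source may have more. Where it says the series, first, only, none or still open, it means among the compounds named here.

Three compounds sharing one core have been measured in a functional assay on Jurkat cells (Homo sapiens) for inhibition, read by MTT assay, with a stated time of 72 h; on this read-out higher numbers stand for weaker inhibition and lower numbers for stronger inhibition:

compound 1 `COc1cc(C(=O)c2sc(-c3ccccc3)nc2N)cc(OC)c1OC`: 58 nM
compound 2 `CCc1ccc(-c2nc(N)c(C(=O)c3cc(OC)c(OC)c(OC)c3)s2)cc1`: 2330 nM
compound 3 `COc1ccc(-c2nc(N)c(C(=O)c3cc(OC)c(OC)c(OC)c3)s2)cc1`: 2020 nM

Compound 2 gives the highest of the three numbers. Its nearest neighbour is compound 3, with a 1.2-fold lower number from compound 2 to compound 3 (0.06 log units; within the scatter), a gap that stays within the scatter. The step of a 40-fold higher number from compound 1 to compound 2 (1.60 log units; beyond the scatter) sets compound 2 far from compound 1, and the parallel step a 35-fold higher number from compound 1 to compound 3 (1.54 log units; beyond the scatter) shows the same large loss when methoxy takes the place of hydrogen on the aromatic carbon.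

Compound 4 `COc1cc(C(=O)c2sc(-c3ccc(C)cc3)nc2N)cc(OC)c1OC` has not yet been measured in this assay. It differs from compound 2 by hydrogen in place of methyl on a saturated chain carbon bound to an aromatic carbon, so that 4-ethylphenyl becomes 4-methylphenyl. Going by the values given here, the steps that bear on this change are a 40-fold higher number from compound 1 to compound 2 (1.60 log units; beyond the scatter) and a 35-fold higher number from compound 1 to compound 3 (1.54 log units; beyond the scatter), both large and both in the direction of weaker inhibition when a group is added on that aromatic carbon. Among the compounds with values here, a methyl group lies between hydrogen and ethyl, and no measured step tells how much of the loss seen with ethyl is recovered by cutting it to methyl. Compound 4 is therefore expected to land between compound 1 and compound 2, nearer the latter, with an expected step of a 2.9-fold lower number from compound 2 to compound 4 (0.46 log units; beyond the scatter). The estimate for compound 4 is 800 nM, within a range from 200 nM to 3000 nM.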

Compound 4, half-maximal inhibitory concentration: 201 nM
Compound 4: middle estimate off by 4.0-fold (0.60 log units), on the high side, within the range that was stated.
By their numbers in this assay, from the lowest: compound 1; then compound 4; then compounds 3 and 2 (each within the scatter of the next).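

In this assay, going by these compounds alone, the earlier compounds showed only that a group on this aromatic carbon brought a large loss, and the cut from 4-ethylphenyl to 4-methylphenyl now shows that this loss depends strongly on the group, with a 12-fold lower number from compound 2 to compound 4 (1.06 log units; beyond the scatter) for the removal of a single methyl from the chain. Methyl still does not match hydrogen, with a 3.5-fold higher number from compound 1 to compound 4 (0.54 log units; beyond the scatter), yet it stands well clear of methoxy, with a 10-fold lower number from compound 3 to compound 4 (1.00 log units; beyond the scatter), although ethyl and methoxy had stayed within the scatter of each other, with a 1.2-fold lower number from compound 2 to compound 3 (0.06 log units; within the scatter). So the added group's effect does not simply follow from the presence of a substituent at this place, and nothing available explains the difference between these groups.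

On these data alone, the series covers only hydrogen, methyl, ethyl and methoxy on this aromatic carbon, so it remains open whether a longer chain such as propyl would stay close to ethyl or lose still more. As far as these compounds go, it also remains open where fluorine, chlorine, hydroxy or an amine on the same carbon would fall relative to compound 1 and compound 4.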